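The source may hold more compounds than are shown below. What is called first, only, known or untested is meant among the compounds shown, and "the series" means these compounds.

Measured compounds:
Compound 1, `Cc1ccc2nc(C(=O)Nc3c(F)cc(-c4cccc(F)c4)cc3F)c(C)c(C(=O)O)c2c1`: 1.53%
Compound 2, `CCc1ccc2nc(C(=O)Nc3c(F)cc(-c4cccc(F)c4)cc3F)c(C)c(C(=O)O)c2c1`: 6.13%

Both compounds were tested in a functional assay on A-375 cells (Homo sapiens) for antiproliferative activity, read by MTT assay, with a stated time of 24 h, tested at 0.41 ug/mL; a higher number here means a stronger effect of the compound at the concentration tested, a lower number a weaker effect. Among the two numbers available, compound 2 stands highest, and its nearest neighbour is compound 1, the only other measured compound; the step of a number 4.6 percentage points higher from compound 1 to compound 2 (within the scatter) lies within the usual scatter, so the two values show no real separation in this assay.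

Compound 3, `Cc1c(C(=O)Nc2c(F)cc(-c3cccc(F)c3)cc2F)nc2ccc(F)cc2c1C(=O)O`, has not yet been measured in this assay. It differs from compound 2 by fluoro in place of ethyl on an aromatic carbon. Among the compounds with values here, the only measured step, from compound 1 to compound 2, concerns a methyl in place of hydrogen on a saturated chain carbon and was small; no measured step bears on a fluoro replacing an ethyl on the aromatic carbon, so there is nothing to suggest a step beyond the scatter in either direction. Both measured values sit at the low end of the scale, and compound 3 is expected to stay there as well. The estimated step of a number 2.1 percentage points lower from compound 2 to compound 3 (within the scatter) is expected to lie within the scatter, and compound 3 is estimated at 4%, within a range from 0% to 15%.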

Compound 3, a percentage reported as inhibition, at one concentration (the size of the read-out at that concentration, not a potency): 3.02%
For compound 3 the middle estimate is 1 percentage points above the measured one, and the stated range covers the measured number.
By their numbers in this assay, from the lowest: compounds 1, 3 and 2 (each within the scatter of the next).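

In this assay, the aromatic carbon that carries the methyl of compound 1 and the ethyl of compound 2 bears a fluoro in compound 3, so this position is now seen with a substituent other than an alkyl group. Replacing ethyl with fluoro gives a number 3.1 percentage points lower from compound 2 to compound 3 (within the scatter), and replacing methyl with fluoro gives a number 1.5 percentage points higher from compound 1 to compound 3 (within the scatter); the earlier pair showed only that methyl and ethyl could not be told apart here, whereas these two steps show that fluoro cannot be told apart from either of them. Nothing at hand offers an explanation for how closely these read-outs lie.

The three compounds therefore leave open whether any group at this position can move the read-out beyond the scatter, for instance an amine, a methoxy group or a longer chain such as butyl. They also share the rest of their structure, so they cannot show what a change elsewhere on the core, such as replacing the carboxylic acid with an ester, would do in this assay.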